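Removing the Amino Group from the Aryl Substituent of Compound 2

This account rests on a few compounds, and the source may have more. Where it says the series, first, only, none or still open, it means among the compounds named here.

Compound 1 `Cc1nc2c3ccccc3ccc2c2nc3c(ccc4ccccc43)c(-c3cccc4ccccc34)c12` gives 64.3 ug/mL in a functional assay, read by spectrophotometry, with a stated time of 15 min; on this read-out lower numbers stand for stronger inhibition and higher numbers for weaker inhibition.
Compound 2 `Cc1nc2c3ccccc3ccc2c2nc3c(ccc4ccccc43)c(-c3ccccc3N)c12` gives 45.6 ug/mL in this assay.
Compound 3 `Cc1nc2c3ccccc3ccc2c2nc3c(ccc4ccccc43)c(C)c12` gives 89.6 ug/mL in this assay.

Of the three numbers shown, compound 2 has the lowest, yet every step from it to a neighbour lies within the scatter, so none of the three can be called more or less active than another on these data. Compound 4 `Cc1nc2c3ccccc3ccc2c2nc3c(ccc4ccccc43)c(-c3ccccc3)c12` differs from compound 2 in a single place: hydrogen in place of amino on an aromatic carbon. Within the data shown here, no measured pair isolates this exact change. Among the measured compounds shown here, the steps that bear on it are those that exchange the whole group on that aromatic carbon: going from a naphthalen-1-yl to the 2-aminophenyl gave a 1.4-fold lower number from compound 1 to compound 2 (0.15 log units; within the scatter), replacing the 2-aminophenyl by methyl gave a 2.0-fold higher number from compound 2 to compound 3 (0.29 log units; within the scatter), and the step of a 1.4-fold higher number from compound 1 to compound 3 (0.14 log units; within the scatter) between the two outer groups was likewise small. Even large swaps on that carbon moved the read-out little, and dropping the amino group alone is thus expected to leave this assay essentially where it stands, with no step beyond the scatter in either direction. The estimated step is a 1.2-fold higher number from compound 2 to compound 4 (0.08 log units; within the scatter). Compound 4 is therefore expected at 55 ug/mL, with a range from 30 ug/mL to 100 ug/mL.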

Compound 4, half-maximal inhibitory concentration: 84.6 ug/mL
Compound 4: middle estimate off by 1.5-fold (0.19 log units), on the low side; measured number inside the range.
By their numbers in this assay, from the lowest: compounds 2, 1, 4 and 3 (each within the scatter of the next).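

In this assay the amino group is now exchanged for hydrogen on its own, with everything else held constant, and this gives a 1.9-fold higher number from compound 2 to compound 4 (0.27 log units; within the scatter). Among these compounds, on these data the amino group therefore cannot be said to matter, even though this is one of the larger steps in the set, and the earlier compounds could only hint at this through swaps of the whole group. Phenyl also fits with the other groups on this carbon, giving a 1.1-fold lower number from compound 3 to compound 4 (0.02 log units; within the scatter) and a 1.3-fold higher number from compound 1 to compound 4 (0.12 log units; within the scatter), so 2-aminophenyl, phenyl, naphthalen-1-yl and methyl all stay within the scatter of one another, with no compound among the four going against this; nothing measured here offers an explanation for that flat picture.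

Whether a carboxylic acid or a longer alkyl chain on this same carbon would also stay within that narrow band remains open, since the groups shown are only aryl groups and methyl. All four compounds also share the core of compound 1 , so what a change elsewhere in that core would do in this assay is equally unknown.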